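Swapping an Ethoxycarbonyl for Propyl on the Anilide Carbonyl

A few compounds are considered here, and "the series" means these few. Any claim that something is new, unique, unknown or untested is made for them only; others in the source may bear on it.

Measured in a functional assay on SiHa cells (Homo sapiens) for inhibition; a lower number here means a stronger inhibitor, a higher number a weaker inhibitor:
- compound 1 `COc1cc(/C=C/C(=O)c2cccc(N)c2)ccc1O` gives 12.3 ug/mL
- compound 2 `COc1cc(/C=C/C(=O)c2cccc(NC(=O)C(C)C)c2)ccc1O` gives 5.96 ug/mL
- compound 3 `CCOC(=O)C(=O)Nc1cccc(C(=O)/C=C/c2ccc(O)c(OC)c2)c1` reaches only a limit, > 50 ug/mL

Compound 3 therefore sits at the limit of > 50 ug/mL in this assay, at which 1 of the 3 values shown sits, with no number of its own. Compound 4 `CCCC(=O)Nc1cccc(C(=O)/C=C/c2ccc(O)c(OC)c2)c1` differs from it by propyl in place of ethoxycarbonyl on a carbonyl carbon. Two measured steps speak to this change. The step of an at least 8.3-fold higher number from compound 2 to compound 3 (0.92 log units; beyond the scatter) went the opposite way, with ethoxycarbonyl replacing an alkyl group on the same carbonyl, and the step of a 2.1-fold lower number from compound 1 to compound 2 (0.31 log units; beyond the scatter) shows that an alkylcarbonyl on the ring nitrogen gives a modestly lower number than hydrogen. Reversing the first step and landing near compound 2, compound 4 is expected to show an at least 7.1-fold lower number from compound 3 to compound 4 (0.85 log units; beyond the scatter) in this assay. The estimate for compound 4 is 7 ug/mL, within 3 ug/mL to 16 ug/mL.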

Compound 4, half-maximal inhibitory concentration: 3.94 ug/mL
Estimate against measurement, compound 4: 1.8-fold (0.25 log units) above; measured number inside the range.
By their numbers in this assay, from the lowest: compounds 4 and 2 (each within the scatter of the next); then compound 1. At a limit, above all of these: compound 3.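

Putting propyl in place of ethoxycarbonyl on the carbonyl carbon gives an at least 12-fold lower number from compound 3 to compound 4 (1.10 log units; beyond the scatter) in this assay, the largest step in this set. That size is only a bound, as compound 3 stands at a limit: the limit of > 50 ug/mL in this assay, at which 1 of the 4 values shown sits.

Propyl and isopropyl read alike here, with a 1.5-fold lower number from compound 2 to compound 4 (0.18 log units; within the scatter), and propylcarbonyl on the ring nitrogen gives a 3.1-fold lower number from compound 1 to compound 4 (0.49 log units; beyond the scatter), so the loss in compound 3 goes with ethoxycarbonyl, not with substitution on that nitrogen as such.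

The compounds shown leave open how a carboxylic acid in place of the ethoxycarbonyl, or a longer chain such as pentyl, would read on this carbonyl carbon.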